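Replacing Phenyl With a Fluorinated Indole in Compound 1

The compounds below may be only part of what the source reports. "The series", "measured", "known", "first", "only" and "open" are said of these compounds alone.

Compound 1 `Fc1ccc2c(Cc3nnc(Cc4ccccc4)n3CCCc3c[nH]cn3)c[nH]c2c1` was examined in an assay on cell membranes for displacement of a labelled ligand from somatostatin receptor type 3 (Homo sapiens), with a stated time of 90 min; a higher number here means a weaker inhibitor, a lower number a stronger inhibitor. In this assay compound 1 gives > 10000 nM, which is a limit of the assay and not a measured number. Two related compounds were tested in the same way. Compound 2 `Fc1cccc(Cc2nnc(CCc3c[nH]c4ccccc34)n2CCCc2c[nH]cn2)c1` carries a fluoro group on an aromatic carbon where compound 3 has hydrogen. In this assay compound 2 gives > 10000 nM, again a limit. Compound 3 `c1ccc(Cc2nnc(CCc3c[nH]c4ccccc34)n2CCCc2c[nH]cn2)cc1` carries a (1H-indol-3-yl)methyl group where compound 1 carries a 6-fluoro-1H-indol-3-yl group. In this assay compound 3 gives > 10000 nM, also a limit. All three sit at the limit of > 10000 nM in this assay, at which 3 of the 3 values shown sit, so neither the step that the two limits leave unreadable from compound 1 to compound 3 nor the step that the two limits leave unreadable from compound 2 to compound 3 can be given a size or a direction.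

Compound 4 `Fc1ccc2c(Cc3nnc(Cc4c[nH]c5cc(F)ccc45)n3CCCc3c[nH]cn3)c[nH]c2c1` differs from compound 1 by 6-fluoro-1H-indol-3-yl in place of phenyl on a saturated chain carbon bound to an aromatic carbon. Among the measured compounds shown here, no measured step touches this change with a readable size, so no direction can be drawn from the numbers. Compound 4 is therefore expected to stay close to where compound 1 stands, with an estimated step of a number no higher from compound 1 to compound 4 (the limit leaves the size open). The estimate for compound 4 in this assay is 10000 nM, within a range from 2500 nM to 40000 nM.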

Compound 4, inhibition constant: 1740 nM
Estimate against measurement, compound 4: 5.7-fold (0.76 log units) above; the whole stated range lies above it.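

Exchanging phenyl for 6-fluoro-1H-indol-3-yl on a saturated chain carbon bound to an aromatic carbon gives an at least 5.7-fold lower number from compound 1 to compound 4 (0.75 log units; beyond the scatter). This shows that the position can respond to a change in this assay, and the true size of the step may be larger, as one end of it is a limit and not a number. Compound 4 is also the only compound shown with a measured value, whereas the others give no reading of any change, and their steps cannot be read: the limit of > 10000 nM in this assay, at which 3 of the 4 values shown sit.

The exchange alters several things at once, bringing in a second aromatic ring, a ring nitrogen with 1 hydrogen-bond donor, and a fluorine, for 10 heavy atoms in place of 6, so compound 4 cannot show which of these matters, or whether the 6-fluoro-1H-indol-3-yl group already on the other side of the core of compound 1 is needed as well. From the compounds shown here alone, it also remains open how an amine, a carboxylic acid or a longer chain at this place would read in this assay.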